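From methyl to hydroxy: an expectation for compound 3

The source may report more compounds than this note shows. Statements on the series, on what has been measured and on what is new or still open speak of the compounds shown alone.

In a functional assay on SW982 cells (Homo sapiens) for inhibition, read by MTT assay, with a stated time of 72 h (a lower number here means a stronger inhibitor, a higher number a weaker inhibitor), compound 1 `COc1ccc(C(=O)/C=C/c2cc(OC)c(OC)cc2OC)cc1` gives 60500 nM and compound 2 `COc1cc(OC)c(OC)cc1/C=C/C(=O)c1ccc(C)cc1` gives 81100 nM. With only these two numbers available, compound 2 stands within the scatter of compound 1.

The next structure is compound 3 `COc1cc(OC)c(OC)cc1/C=C/C(=O)c1ccc(O)cc1`, which carries hydroxy in place of methyl on an aromatic carbon, para to a large group: hydroxy in place of methyl on an aromatic carbon. The same difference reads 4-methylphenyl to 4-hydroxyphenyl.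

Going by the values given here, one measured step bears on it, a 1.3-fold higher number from compound 1 to compound 2 (0.13 log units; within the scatter), where methyl takes the place of methoxy on the same aromatic carbon. That exchange did not move the number beyond the scatter. Among the compounds with values here, no measured compound carries hydroxy at this place, and a single step is thin evidence, so the range is kept wide.

The expected change in this assay is a 1.5-fold lower number from compound 2 to compound 3 (0.17 log units; within the scatter), which means no expected shift beyond the scatter in either direction. For compound 3 the estimate is 55000 nM, with an expected range of 22000 nM to 120000 nM.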

Compound 3, half-maximal inhibitory concentration: 155000 nM
Beside the measured number, compound 3's estimate is 2.8-fold (0.45 log units) below it; the whole stated range lies below it.
By their numbers in this assay, from the lowest: compounds 1, 2 and 3 (each within the scatter of the next, the first and the last beyond it).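

In this assay, hydroxy in place of methyl on this aromatic carbon, para to a large group, gives a 1.9-fold higher number from compound 2 to compound 3 (0.28 log units; within the scatter) and so, taken alone, does not move the number beyond the scatter. Hydrogen in place of methyl on the oxygen at the same place, which turns the methoxy group of compound 1 into the hydroxy group of compound 3, gives a 2.6-fold higher number from compound 1 to compound 3 (0.41 log units; beyond the scatter) and is the first step in these notes to pass the scatter, though only modestly; the earlier exchange of methoxy for methyl did not show this, so the place is no longer one where every exchange tested stays within the scatter. Nothing at hand gives any measured property of these compounds that would account for this difference.

From the compounds shown here alone, it remains open whether an amine or a carboxylic acid at this place would stand beyond the scatter from compound 2, or whether a longer chain on the oxygen would stand beyond the scatter from compound 1. Going by these compounds, it also remains open whether hydroxy in place of methoxy would give a similar step at any other place on the shared core.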